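Compound 3 Loses Its Boron-Bearing Group for Phenyl

The source may hold more compounds than are shown below. What is called first, only, known or untested is meant among the compounds shown, and "the series" means these compounds.

In a functional assay on SK-OV-3 cells (Homo sapiens) for antiproliferative activity, read by MTT assay, with a stated time of 72 h (a higher number here means a weaker inhibitor, a lower number a stronger inhibitor), compound 3 `COc1cc(OC)cc(-c2cccc(NC(=O)CCc3cccc4c3COB4O)c2)c1` gives 88000 nM, within the scatter of compound 2 `COc1cc(OC)cc(-c2cccc(NC(=O)CCc3ccc4c(c3)COB4O)c2)c1` at 93000 nM, whereas compound 1 `COc1cc(OC)cc(-c2cccc(NC(=O)CCc3cccc4c3B(O)OC4)c2)c1` gives 44 nM. Compound 4 `COc1cc(OC)cc(-c2cccc(NC(=O)CCc3ccccc3)c2)c1` differs from compound 3 by a group of 6 heavy atoms (6 carbon; one six-membered aromatic ring of carbon only) in place of a group of 10 heavy atoms (7 carbon, 1 boron, 2 oxygen; one five-membered non-aromatic ring with 2 hetero atoms, one six-membered aromatic ring of carbon only), on a saturated chain carbon, two bonds along the chain from a carbonyl carbon. Among the measured compounds shown here, no measured step shows this exchange directly. The nearest guides are the small 1.1-fold lower number from compound 2 to compound 3 (0.02 log units; within the scatter) and the large 2100-fold higher number from compound 1 to compound 2 (3.33 log units; beyond the scatter) and a 2000-fold higher number from compound 1 to compound 3 (3.30 log units; beyond the scatter). Only compound 1 stands apart, so compound 3, with its 88000 nM, is the expected reference, and no step beyond the scatter is expected in this assay. The expected change is a 1.3-fold lower number from compound 3 to compound 4 (0.10 log units; within the scatter). For compound 4 the estimate is 70000 nM, within an expected range of 12000 nM to 200000 nM.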

Compound 4, half-maximal inhibitory concentration: > 100000 nM
Compound 4: only a limit was reported (the forecaster's own chance of this, stated with the estimate: 35%); middle value at least 1.4-fold (0.15 log units) from the limit.
By their numbers in this assay, from the lowest: compound 1; then compounds 3 and 2 (each within the scatter of the next). At a limit, above all of these: compound 4.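

In this assay compound 4 gives only a limit of the assay, not a number: the limit of > 100000 nM in this assay, at which 1 of the 4 values shown sits. The phenyl exchange reads as an at least 1.1-fold higher number from compound 3 to compound 4 (0.05 log units; that floor lies within the scatter) and as an at least 1.0-fold higher number from compound 2 to compound 4 (0.03 log units; that floor lies within the scatter), floors that do not part compound 4 from either compound. Against this, an at least 2200-fold higher number from compound 1 to compound 4 (3.35 log units; beyond the scatter) shows that, among these compounds, only the boron-bearing group as attached in compound 1 stands clearly apart from plain phenyl. From the compounds shown here alone, how far compound 4 lies past its limit stays open, as does whether a carboxylic acid on the phenyl could recover any of the low number of compound 1.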